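The source may hold more compounds than are shown below. What is called first, only, known or untested is meant among the compounds shown, and "the series" means these compounds.

Measured so far in an assay for binding affinity to 17-beta-hydroxysteroid dehydrogenase 14 (Homo sapiens), read by fluorescence, with a stated time of 15 min, in the presence of a further agent that is not named here; on this read-out higher numbers stand for weaker inhibition and lower numbers for stronger inhibition:
compound 1 `O=C(c1ccc(F)c(O)c1)c1ccc2cc(O)ccc2n1` gives 119 nM
compound 2 `O=C(Nc1cccc(-c2cccc(O)c2F)n1)c1ccc(F)c(O)c1` gives 686 nM

Compound 1 holds the lower of the two numbers in this assay; compound 2 sits at a higher number, and the gap between them lies beyond the usual scatter. For the measured compounds named here, no step between measured compounds that differ in one place is available, so nothing measured yet shows how much the hydroxy on the core of compound 1 contributes.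

Compound 3 `Cc1ccc2nc(C(=O)c3ccc(F)c(O)c3)ccc2c1` follows from compound 1 by a single change: methyl in place of hydroxy on an aromatic carbon. The change removes a hydrogen-bond donor and a hydrogen-bond acceptor from the core and brings none in their place. Going by the values given here, with no measured pair to calibrate this, the expectation rests on the change alone: a shift toward a higher number in this assay, of moderate size and probably beyond the scatter, is expected. Compound 3 is estimated at 450 nM, with a range from 130 nM to 1600 nM. The step of a 3.8-fold higher number from compound 1 to compound 3 (0.58 log units; beyond the scatter) is expected to be moderate rather than large.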

Compound 3, inhibition constant: 6 nM
The estimate for compound 3 lay 75-fold (1.88 log units) above the measured number; measured number below the stated range.
By their numbers in this assay, from the lowest: compound 3; then compound 1; then compound 2.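

In this assay, methyl in place of hydroxy on this aromatic carbon of the shared core gives a 20-fold lower number from compound 1 to compound 3 (1.30 log units; beyond the scatter), a large step and the first calibration of this position. The hydroxy on the core of compound 1 is therefore not required for a low number in this assay, and the hydrogen-bond donor and acceptor that leave with it are not needed in this pair. Nothing available bears on the reason for this step, so it stands as an observation from a single pair.

The compounds shown leave open whether the step reflects the arrival of methyl, the departure of hydroxy or both, a question that an unsubstituted hydrogen at the same carbon could separate. They also leave open how far this position tolerates other groups, such as methoxy, an amine, a carboxylic acid, chlorine or a longer chain like ethyl, and whether the effect of this change would carry over to other members of the series.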